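The source may report more compounds than this note shows. Statements on the series, on what has been measured and on what is new or still open speak of the compounds shown alone.

Measured compounds:
compound 1, `C#CCNC1CCc2c(SCCc3cccc(C)c3)cccc21`: 4960 nM
compound 2, `C#CCNC1CCc2c(SCc3cccc(C)c3)cccc21`: > 100000 nM
compound 3, `C#CCNC1CCc2c(SCc3ccc(F)cc3F)cccc21`: 1480 nM

All three were tested in an ADME assay on isolated protein for inhibition of Amine oxidase [flavin-containing] B (Homo sapiens); a higher number here means a weaker inhibitor, a lower number a stronger inhibitor. Compound 1 gives 4960 nM, the highest of the two numbers reported, and so the weakest inhibitor among the compounds with a number; the nearest is compound 3 at 1480 nM, whose number is lower by more than the usual scatter. Compound 2 gives > 100000 nM, which is a limit of the assay and not a number.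

The step in question leads from compound 1 to compound 4, `C#CCNC1CCc2c(SCCc3cccc(F)c3)cccc21`, not yet measured in this assay. The change is fluoro in place of methyl on an aromatic carbon. Within the data shown here, no measured pair shows exactly this exchange, so the size of the step cannot be read from the data. The estimate rests only on compound 1 at 4960 nM, and a step of a 1.3-fold lower number from compound 1 to compound 4 (0.12 log units; within the scatter) is expected, small and in no direction that stands out beyond the scatter. Compound 4 is therefore expected to give about 3800 nM in this assay, with a plausible range from 1200 nM to 12000 nM.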

Compound 4, half-maximal inhibitory concentration: 7810 nM
For compound 4 the middle estimate is 2.1-fold (0.31 log units) below the measured one; measured number inside the range.
By their numbers in this assay, from the lowest: compound 3; then compounds 1 and 4 (each within the scatter of the next). At a limit, above all of these: compound 2.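

In this assay, putting fluoro in place of methyl on this aromatic carbon, meta to a large group, gives a 1.6-fold higher number from compound 1 to compound 4 (0.20 log units; within the scatter). Among these compounds, this is the first direct comparison at this position, and it shows that the change from 3-methylphenyl to 3-fluorophenyl leaves the number indistinguishable from repeat-measurement noise, so for this pair the two groups cannot be told apart in this assay. Nothing among the data shown offers a reason for this result.

A single pair cannot show whether the same exchange would behave alike on the different linker of compound 2. It also leaves open whether a group of another kind at this position, such as an amine, a carboxylic acid or a methoxy group, would move the number beyond the scatter.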